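From carbamoyl to methoxy on compound 1

This account rests on a few compounds, and the source may have more. Where it says the series, first, only, none or still open, it means among the compounds named here.

Compound 1, `Cc1cc(NC(=O)Nc2cccc(C(N)=O)c2)c2ccccc2n1`, was tested in an ADME assay on BJ cells (Homo sapiens) for cytotoxicity, with a stated time of 72 h; on this read-out lower numbers stand for an effect already at smaller amounts and higher numbers for an effect only at larger amounts of compound. Compound 1 gives only a limit, > 25000 nM, and not a number. Compound 2, `Cc1cc(NC(=O)Nc2ccc(SC(F)(F)F)cc2)c2ccccc2n1`, also stops at a limit, > 25000 nM. Compound 3, `Cc1cc(NC(=O)Nc2ncccc2C)c2ccccc2n1`, likewise gives the limit > 25000 nM. Within the data shown here, the series so far therefore offers a single reading, (the limit of > 25000 nM in this assay, at which 3 of the 3 values shown sit), and no measured pair differs in one place only.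

Compound 4, `COc1cccc(NC(=O)Nc2cc(C)nc3ccccc23)c1`, has not yet been measured. It carries methoxy in place of carbamoyl on an aromatic carbon, meta to a large group (methoxy in place of carbamoyl on an aromatic carbon).

In this assay no step beyond the usual scatter is expected, in either direction. This expectation rests on compound 1, whose reading of > 25000 nM is a limit. The estimated change is a number no higher from compound 1 to compound 4 (the limit leaves the size open), and it is expected to stay within the scatter. For compound 4 the expected value is 25000 nM, with an estimated range from 12000 nM to 50000 nM.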

Compound 4, half-maximal effective concentration: 27000 nM
Beside the measured number, compound 4's estimate is 1.1-fold (0.03 log units) below it, and the stated range covers the measured number.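

No step can be read from compound 1 to compound 4, because compound 1 is known only as a limit: the limit of > 25000 nM in this assay, at which 3 of the 4 values shown sit.

The compounds shown leave open how far compound 4 lies from compound 1, and whether any change on the shared core brings an effect at smaller amounts.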